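Ethylsulfonyl for acetyl on the amine nitrogen

The source may report more compounds than this note shows. Statements on the series, on what has been measured and on what is new or still open speak of the compounds shown alone.

Among the measured compounds shown here, compound 1 `CCOC(=O)N(Cc1ccccc1Oc1ccccc1)[C@H]1CCNC1` is the only member of the series with a number: in an assay on HEK293 cells for inhibition of sodium-dependent dopamine transporter (Homo sapiens) (on this read-out lower numbers stand for stronger inhibition and higher numbers for weaker inhibition), compound 1 gives 1900 nM. Compound 2 `CC(=O)N(Cc1ccccc1-c1ccccc1)[C@H]1CCNC1` carries an acetyl group on the amine nitrogen; in this assay compound 2 is recorded as "not determined" (no result reported). Compound 3 `CN1CC[C@H](N(Cc2ccccc2-c2ccccc2)S(C)(=O)=O)C1` is likewise without a result, recorded in this assay as "not determined" (no result reported). So compound 2 stands nowhere on the numbers shown. Compound 4 `CCS(=O)(=O)N(Cc1ccccc1-c1ccccc1)[C@H]1CCNC1` differs from compound 2 by ethylsulfonyl in place of acetyl on an amine nitrogen. For the measured compounds named here, no measured step covers this change, so neither size nor direction can be read from the series; the only anchor is compound 1 with its 1900 nM. Compound 4 is expected to give about 1500 nM, with a range of 300 nM to 8000 nM in this assay.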

Compound 4, inhibition constant: 2760 nM
Compound 4: the middle estimate sits 1.8-fold (0.26 log units) below what was measured; the range from low to high includes it.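

No step can be read between compound 2 and compound 4, as compound 2 has no single number. Nothing at hand bears on the result. Going by these compounds, what ethylsulfonyl in place of acetyl does to inhibition stays open.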